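The compounds below may be only part of what the source reports. "The series", "measured", "known", "first", "only" and "open" are said of these compounds alone.

Measured in a functional assay on MCF7 cells (Homo sapiens) for cytotoxicity, read by fluorescence, with a stated time of 72 h; a higher number here means a weaker inhibitor, a lower number a stronger inhibitor:
- compound 1 `CC(C)c1n[nH]c2c(NCc3ccc(-c4ccccn4)cc3)nc(S(C)(=O)=O)nc12`: 460 nM
- compound 2 `CC(C)c1n[nH]c2c(NCc3ccc(-c4ccccn4)cc3)nc(NCCO)nc12`: 51 nM
- compound 3 `CC(C)c1n[nH]c2c(NCc3ccc(-c4ccccn4)cc3)nc(N[C@@H]3CCCC[C@H]3N)nc12`: 295 nM

On these numbers, compound 3 cannot be told apart from compound 1, as a 1.6-fold lower number from compound 1 to compound 3 (0.19 log units; within the scatter) shows. Compound 2 has the lowest number of the three, with a 9.0-fold lower number from compound 1 to compound 2 (0.96 log units; beyond the scatter) and a 5.8-fold higher number from compound 2 to compound 3 (0.76 log units; beyond the scatter).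

Compound 4 `CC(C)c1n[nH]c2c(NCc3ccc(-c4ccccn4)cc3)nc(NCCN(C)C)nc12` keeps the shared core and changes one side chain: 2-(dimethylamino)ethyl in place of 2-aminocyclohexyl on a nitrogen on an aromatic ring. Here 2-(dimethylamino)ethyl takes the place of 2-aminocyclohexyl on a nitrogen on an aromatic ring. The entering group has no ring, and neither does the 2-hydroxyethyl group of compound 2.

The closest guide is therefore a 5.8-fold higher number from compound 2 to compound 3 (0.76 log units; beyond the scatter), a modest step that leads away from that ringless chain. Within the data shown here, no measured compound carries 2-(dimethylamino)ethyl, so only part of that step is expected to be undone. The expected change in this assay is a 2.5-fold lower number from compound 3 to compound 4 (0.39 log units; beyond the scatter), a small move towards a lower number.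

Compound 4 is estimated at 120 nM, with an expected range of 40 nM to 350 nM.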

Compound 4, half-maximal inhibitory concentration: 225 nM
Compound 4: the middle estimate sits 1.9-fold (0.27 log units) below what was measured; measured number inside the range.
By their numbers in this assay, from the lowest: compound 2; then compounds 4, 3 and 1 (each within the scatter of the next, the first and the last beyond it).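

In this assay, replacing the ring-bearing 2-aminocyclohexyl with the ringless 2-(dimethylamino)ethyl makes no readable difference (a 1.3-fold lower number from compound 3 to compound 4 (0.12 log units; within the scatter)). Removing the ring and both defined stereocentres therefore does not bring the number close to that of compound 2, as a ringless chain alone is not enough: with dimethylamino in place of hydroxy on the saturated chain carbon, the step is modest but clear (a 4.4-fold higher number from compound 2 to compound 4 (0.64 log units; beyond the scatter)). The new chain also separates modestly from the methylsulfonyl group (a 2.0-fold lower number from compound 1 to compound 4 (0.31 log units; beyond the scatter)), yet of these four groups only the 2-hydroxyethyl chain of compound 2 lies beyond the scatter of all the others.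

No supporting measurement explains the gap between the hydroxy and dimethylamino chains. On these data alone, it remains open whether a 2-aminoethyl chain, with its primary amine, or the longer 3-hydroxypropyl chain would fall nearer compound 2 or compound 4.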